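Sulfanyl to sulfonyl step in the butyl hydroxyurea series

The source may report more compounds than this note shows. Statements on the series, on what has been measured and on what is new or still open speak of the compounds shown alone.

Measured so far:
compound 1 `CCCCN(O)C(=O)Nc1cc([C@@H]2CC[C@@H](c3cc(OC)c(OC)c(OC)c3)O2)cc(OC)c1OCCSc1ccc(Br)cc1` — 21 nM
compound 2 `CCCCN(O)C(=O)Nc1cc([C@@H]2CC[C@@H](c3cc(OC)c(OC)c(OC)c3)O2)cc(OC)c1OCCSc1cccc(Br)c1` — 22 nM

In an assay for displacement of a labelled ligand from platelet-activating factor receptor (Homo sapiens) (on this read-out higher numbers stand for weaker inhibition and lower numbers for stronger inhibition), compound 1 gives 21 nM and compound 2 gives 22 nM. The single step between them, a 1.0-fold higher number from compound 1 to compound 2 (0.02 log units; within the scatter), leaves the two within the scatter of each other, so compound 2 stands level with compound 1 on the numbers shown.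

Compound 3 `CCCCN(O)C(=O)Nc1cc([C@@H]2CC[C@@H](c3cc(OC)c(OC)c(OC)c3)O2)cc(OC)c1OCCS(=O)(=O)c1ccc(Br)cc1` is not yet measured. It differs from compound 2 by (4-bromophenyl)sulfonyl in place of (3-bromophenyl)sulfanyl on a saturated chain carbon, two bonds along the chain from an oxygen on an aromatic ring. For the measured compounds named here, two things move at once here: the bromine position, for which the step from compound 1 to compound 2 shows no change beyond the scatter, and the sulfanyl to sulfonyl exchange, for which no measured step exists in this set. The first part is therefore expected to contribute nothing; for the second part the data give no direction.

Compound 3 is estimated at 40 nM in this assay, with a range of 10 nM to 200 nM, the expected step being a 1.8-fold higher number from compound 2 to compound 3 (0.26 log units; within the scatter).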

Compound 3, half-maximal inhibitory concentration: 38 nM
The estimate for compound 3 lay 1.1-fold (0.02 log units) above the measured number; measured number inside the range.
By their numbers in this assay, from the lowest: compounds 1, 2 and 3 (each within the scatter of the next).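

In this assay, for the compounds shown here, (4-bromophenyl)sulfonyl in place of (4-bromophenyl)sulfanyl gives the first direct reading of the sulfanyl to sulfonyl exchange on this saturated chain carbon, two bonds along the chain from an oxygen on an aromatic ring (a 1.8-fold higher number from compound 1 to compound 3 (0.26 log units; within the scatter)). The step that also moves the bromine reads the same way (a 1.7-fold higher number from compound 2 to compound 3 (0.24 log units; within the scatter)), so on these numbers neither the bromine position nor the sulfonyl oxygens separate the three compounds. No measurement shown bears on why the exchange leaves the number within the scatter.

Still open, on these data alone, is whether a sulfinyl group or an amine in place of the sulfur would also stay within the scatter in this assay. Also open, as far as these compounds go, is whether a longer chain than the 2-((4-bromophenyl)sulfonyl)ethyl group, or a carboxylic acid in place of the bromine, would do the same.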